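A limit and an expectation for compound 3

The source may hold more compounds than are shown below. What is called first, only, known or untested is meant among the compounds shown, and "the series" means these compounds.

Values so far in a functional assay on U-87MG ATCC cells for antiproliferative activity against U-87 MG (Homo sapiens), read by MTT assay (on this read-out higher numbers stand for weaker inhibition and lower numbers for stronger inhibition), both of them limits of the assay and not numbers:
Compound 1 (`Cc1cc(=O)c(O)c(Cc2ccc(F)cc2)o1`) gives > 50000 nM
Compound 2 (`Cc1cc(=O)c(O)c(C(c2ccc(OCc3ccc([N+](=O)[O-])cc3)cc2)c2oc(C)cc(=O)c2O)o1`) gives > 50000 nM

Compound 2 has no numerical value to place it. Its entry of > 50000 nM is a limit, and the whole record so far is the limit of > 50000 nM in this assay, at which 2 of the 2 values shown sit. Compound 1 shares that limit, so the two cannot be ranked against each other.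

Compound 3 (`CCCOc1ccc(C(c2oc(C)cc(=O)c2O)c2oc(C)cc(=O)c2O)cc1`) has ethyl in place of 4-nitrophenyl on a saturated chain carbon bound to an oxygen on an aromatic ring. The same difference, cut one bond further out, reads 4-nitrobenzyl to propyl.

Within the data shown here, no measured step between two compounds is available as a guide to the size of this change in this assay. The expectation is therefore for no change beyond the scatter, and a reading that again returns only a limit is the likeliest result. The expected move is a number no higher from compound 2 to compound 3 (the limit leaves the size open) (an estimate only). For compound 3 the estimated value is 50000 nM (expected range 20000 nM to 100000 nM).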

Compound 3, half-maximal inhibitory concentration: 29500 nM
Compound 3: the middle estimate sits 1.7-fold (0.23 log units) above what was measured, and the stated range covers the measured number.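

In this assay, among these compounds, compound 3 is the first of the series to return a number rather than a limit, so this position can now be read on a scale. Setting propoxy in place of (4-nitrobenzyl)oxy, that is, ethyl in place of 4-nitrophenyl on a saturated chain carbon bound to an oxygen on an aromatic ring, gives an at least 1.6-fold lower number from compound 2 to compound 3 (0.22 log units; that floor lies within the scatter). This shows that a reading inside the range of the assay does not need the 4-nitrophenyl ring, but the true size of the step stays unknown, and the floor alone does not establish a real difference, because one end of it is only a limit: the limit of > 50000 nM in this assay, at which 2 of the 3 values shown sit.

The compounds shown leave open whether the reading at this position follows chain length, as a longer chain such as butyl or a shorter one such as methyl on the same oxygen would test. They also leave open whether an amine or a carboxylic acid at the end of the propyl chain would move the number at all, and whether any group here can give much stronger inhibition than compound 3, which reads 29500 nM.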